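This account rests on a few compounds, and the source may have more. Where it says the series, first, only, none or still open, it means among the compounds named here.

Compound 1 `CNC(=O)N1CCCc2ccc(NC(=O)c3cccc(-c4cnn(C)c4)c3)cc21` was measured in a functional assay on MV4-11 cells (Homo sapiens) for antiproliferative activity, with a stated time of 6 days, tested at 1.56 uM (a lower number here means a weaker effect, a higher number a stronger effect of the compound at the concentration tested), and gives 71.2%, the lower of the two numbers available. Its companion compound 2 `CNC(=O)N1CCCc2ccc(NC(=O)c3ccc(-c4cn[nH]c4)cc3)cc21` gives 73.5% in this assay, a figure within the usual scatter of the value of compound 1, so the two read as equal. Compound 3 `CNC(=O)N1CCCc2ccc(NC(=O)c3cccc(-c4ccn(C(C)=O)n4)c3)cc21` is not yet measured. It differs from compound 1 in one place: 1-acetyl-1H-pyrazol-3-yl in place of 1-methyl-1H-pyrazol-4-yl on an aromatic carbon. For the measured compounds named here, no step between measured compounds covers a change of this kind, so nothing in the data says which way it will go. Going by the values given here, with only two near-identical values to lean on, compound 3 is expected to stay in the same region, and the estimated step of a number 9.2 percentage points lower from compound 1 to compound 3 (within the scatter) in this assay is expected to be small and likely not beyond the scatter. Compound 3 is accordingly expected to give about 62%, within a range from 35% to 82%.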

Compound 3, a percentage reported as inhibition, at one concentration (the size of the read-out at that concentration, not a potency): 27.6%
Compound 3: middle estimate off by 34.4 percentage points, on the high side; the whole stated range lies above it.
By their numbers in this assay, from the lowest: compound 3; then compounds 1 and 2 (each within the scatter of the next).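

In this assay, the position meta to a large group on the six-membered aromatic ring proves not to be indifferent to the heteroaryl group it carries: a number 43.6 percentage points lower from compound 1 to compound 3 (beyond the scatter). For the compounds shown here, the near-equal values of compounds 1 and 2 had given no sign of this, and the new step is the first change to lie beyond the scatter. Nothing available explains the loss of effect.

The change alters two things at once, the substituent on the pyrazole nitrogen and the ring carbon through which the pyrazole attaches, so the compounds shown cannot assign the drop to either. From the compounds shown here alone, the 1-methyl-1H-pyrazol-3-yl and 1-acetyl-1H-pyrazol-4-yl groups, each of which would separate these two features, remain open at this position.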